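The source may report more compounds than this note shows. Statements on the series, on what has been measured and on what is new or still open speak of the compounds shown alone.

Compound 1 `CC(=O)O[C@@]1(C)CCC(=O)[C@H](C)CCC[C@]2(C)O[C@H]2C(=O)C(=C(C)C)CC1`: 19500 nM
Compound 2 `CC(C)=C1CC[C@]2(C)CC[C@]3(O[C@H](C[C@H]3C)C[C@]3(C)O[C@H]3C1=O)O2`: > 50000 nM

Both results come from a functional assay on NCI-H1299 cells (Homo sapiens) for cytotoxicity, read by MTT assay, with a stated time of 24 h; on this read-out higher numbers stand for weaker inhibition and lower numbers for stronger inhibition. In this assay, compound 1 gives a true measured number, 19500 nM. Compound 2 stands elsewhere, and its result of > 50000 nM is a limit of the assay and not a number.

The next compound, compound 3 `CC(C)=C1CC[C@]2(C)CC[C@]3(O[C@H](C[C@@H]3C)C[C@]3(C)O[C@H]3C1=O)O2`, has not yet been tested in this assay. It is a very close relative of compound 2, and the whole difference lies in how one centre is drawn in space: the two compounds have the same atoms and bonds and differ only in configuration as drawn: 1 of 6 stereo elements differ; a stereocentre at a saturated ring carbon is drawn R in compound 2 and S in compound 3. Such compounds, alike in every bond, are a clean test of whether the spatial arrangement at one carbon matters to the read-out.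

Within the data shown here, no pair of measured compounds shows what a change of this kind does here, and compound 1 has a different structure, so it offers little guidance. The expectation therefore rests on compound 2 alone. The expected step that the limit leaves unreadable from compound 2 to compound 3 is none beyond the scatter, and another limit would be no surprise. For compound 3 the estimated value is 55000 nM, with an expected range of 25000 nM to 120000 nM.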

Compound 3, half-maximal inhibitory concentration: > 50000 nM
Compound 3: only a limit was reported (the forecaster's own chance of this, stated with the estimate: 70%); the middle value is on the limit's open side.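

No step can be read from compound 2 to compound 3 in this assay, because both results are limits of the assay and not numbers: the limit of > 50000 nM in this assay, at which 2 of the 3 values shown sit. The compounds shown leave open whether the spatial arrangement at this one carbon affects the read-out at all, and this pair is the direct test of that: the fact that compounds 2 and 3 differ only in the configuration as drawn.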